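Shifting a methyl around the benzyl ring of compound 3

The compounds below may be only part of what the source reports. "The series", "measured", "known", "first", "only" and "open" are said of these compounds alone.

Three compounds share one core and differ only in the benzyl group: compound 1 `Nc1nc(NCc2ccccc2F)nc(-c2ccccc2CO)n1`, compound 2 `Nc1nc(NCc2cccc(Cl)c2)nc(-c2ccccc2CO)n1` and compound 3 `Cc1cccc(CNc2nc(N)nc(-c3ccccc3CO)n2)c1`. In a functional assay on cells for positive allosteric modulation of G-protein coupled receptor 68 (Homo sapiens), read by a luciferase reporter and cAMP accumulation, with a stated time of 30 min, at pH 6.8 and pH 8.3, in the presence of a further agent that is not named here (on this read-out lower numbers stand for lower potency and higher numbers for higher potency (the scale is a negative logarithm)), compound 1 gives 4.27, compound 2 gives 4.97 and compound 3 gives 4.4. Compound 3 stands second of the three, close to compound 1 and below compound 2, as a number 0.57 log units lower from compound 2 to compound 3 (beyond the scatter) shows; a number 0.70 log units higher from compound 1 to compound 2 (beyond the scatter) and a number 0.13 log units higher from compound 1 to compound 3 (within the scatter) complete the picture. Compound 4 `Cc1ccc(CNc2nc(N)nc(-c3ccccc3CO)n2)cc1` is the unmeasured partner: 4-methylphenyl in place of 3-methylphenyl on a saturated chain carbon bound to a nitrogen on an aromatic ring. Among the compounds with values here, no measured step moves a substituent around the ring, so the steps seen concern other changes. The change from compound 3 to compound 4 is therefore expected to stay within the scatter, a number 0.05 log units lower from compound 3 to compound 4 (within the scatter). Compound 4 is estimated at 4.35, between 3.85 and 4.9.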

Compound 4, negative logarithm of the antagonist equilibrium constant: 4.38
The estimate for compound 4 lay 0.03 log units below the measured number; measured number inside the range.
By their numbers in this assay, from the lowest: compounds 1, 4 and 3 (each within the scatter of the next); then compound 2.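

The 3-methylphenyl and 4-methylphenyl groups cannot be told apart in this assay (a number 0.02 log units lower from compound 3 to compound 4 (within the scatter)), so on this carbon the place of the methyl on the ring leaves no readable mark. The 4-methylphenyl group also cannot be told apart from 2-fluorophenyl (a number 0.11 log units higher from compound 1 to compound 4 (within the scatter)), while 3-chlorophenyl remains separate from it (a number 0.59 log units lower from compound 2 to compound 4 (beyond the scatter)). Nothing available explains these numbers.

From the compounds shown here alone, whether chloro would keep its higher number as 4-chlorophenyl remains open. So does what a methoxy group or a longer chain would do at this place.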